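Replacing the Sulfonamide Hydrogen on a Fused Bicyclic Core

The compounds below may be only part of what the source reports. "The series", "measured", "known", "first", "only" and "open" are said of these compounds alone.

Compound 1 `CCCS(=O)(=O)Nc1cccc2c1CCCC2c1c[nH]cn1` was measured in an assay on isolated protein for binding affinity to Alpha-1A adrenergic receptor (Rattus norvegicus), read by radioligand binding (a lower number here means a stronger inhibitor, a higher number a weaker inhibitor), and gives 1700 nM. For the measured compounds named here, that is the highest number among the three compounds measured so far: compound 2 `CS(=O)(=O)Nc1cccc2c1OCCC2c1c[nH]cn1` gives 479 nM, and compound 3 `CCS(=O)(=O)Nc1cc(F)cc2c1CCCC2c1c[nH]cn1` gives 83.2 nM, both differences from compound 1 being beyond the scatter. Compound 4 `CN(c1cccc2c1CCCC2c1c[nH]cn1)S(C)(=O)=O` has not yet been measured. It differs from compound 1 in one place: methyl(methylsulfonyl)amino in place of (propylsulfonyl)amino on an aromatic carbon The sulfonamide hydrogen of compound 1 is thus gone, and the chain on the sulfonyl group is shorter. Going by the values given here, no measured pair in this set shows what such a change does, so the direction is uncertain; a modest weakening, close to the scatter, is expected as a 1.5-fold higher number from compound 1 to compound 4 (0.17 log units; within the scatter). Compound 4 is therefore estimated at 2500 nM, within a range of 600 nM to 10000 nM.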

Compound 4, inhibition constant: 204 nM
Beside the measured number, compound 4's estimate is 12-fold (1.09 log units) above it, outside the stated range (below it).
By their numbers in this assay, from the lowest: compound 3; then compound 4; then compound 2; then compound 1.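

In this assay, methyl(methylsulfonyl)amino in place of (propylsulfonyl)amino on an aromatic carbon gives an 8.3-fold lower number from compound 1 to compound 4 (0.92 log units; beyond the scatter) and so lowers the number rather than raising it. This position therefore accepts a group without the sulfonamide hydrogen, and with a shorter chain on the sulfonyl group. No supporting data here explain the gain. Both edits arrive together, so the compounds shown leave open which of them carries the step. Also open, as far as these compounds go, is how a larger group on that nitrogen, such as ethyl or benzyl, would read.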